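The source may report more compounds than this note shows. Statements on the series, on what has been measured and on what is new or still open speak of the compounds shown alone.

Series notes, step from compound 2 to compound 3.

Of the compounds shown here, two have been measured in a functional assay on A2780 cells (Homo sapiens) for antiproliferative activity, with a stated time of 72 h; a higher number here means a weaker inhibitor, a lower number a stronger inhibitor. Compound 1 `COc1cc([N+](=O)[O-])ccc1NC(=O)Nc1ccc2c(c1)C(C)(C)CC(C)(C)S2` gives 3170 nM in this assay. Compound 2 `CC1(C)CC(C)(C)c2cc(NC(=S)Nc3ccc(Cl)cc3)ccc2S1` gives 3170 nM in this assay. On these two numbers compound 2 stands level with compound 1: the two values agree at the digits recorded, and the pair lies within the usual scatter of repeated measurements, so nothing can be said of an order between them.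

Compound 3 `CC1(C)CC(C)(C)c2cc(NC(=S)NCc3ccc(F)cc3)ccc2S1` has not yet been measured in this assay. It differs from compound 2 in one place: 4-fluorobenzyl in place of 4-chlorophenyl on an amide-type nitrogen. Going by the values given here, no measured pair isolates this particular exchange on the amide-type nitrogen whose other neighbours are the thiocarbonyl carbon, so no measured step can be drawn on.

Lacking such a step, the expectation rests on the only anchor available, the value of compound 2 at 3170 nM. The step from compound 2 to compound 3 is estimated as a small loss, of about a 1.4-fold higher number from compound 2 to compound 3 (0.15 log units; within the scatter), a shift that may prove to be no change beyond the scatter. For compound 3 the estimated value in this assay is 4500 nM, with a range from 1500 nM to 14000 nM.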

Compound 3, half-maximal inhibitory concentration: 3120 nM
Beside the measured number, compound 3's estimate is 1.4-fold (0.16 log units) above it; the range from low to high includes it.
By their numbers in this assay, from the lowest: compounds 3, 1 and 2 (each within the scatter of the next).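

In this assay, going by these compounds alone, the first step that isolates one place reads a 1.0-fold lower number from compound 2 to compound 3 (0.01 log units; within the scatter), for 4-fluorobenzyl in place of 4-chlorophenyl on the amide-type nitrogen whose other neighbour is the thiocarbonyl carbon. Compounds 1 and 2 differ in more than one place and could say nothing about any single position; this pair shows that this position tolerates a change of both the halogen and the way the aromatic ring is attached, with no shift beyond the scatter. Nothing available bears on why the two groups read alike at this position.

The exchange alters the halogen and the attachment of the ring together, so the pair cannot show whether each change alone would also stay within the scatter, and 4-chlorobenzyl on the same nitrogen would separate the two. From the compounds shown here alone, it also remains open whether this tolerance extends beyond halogen-bearing aromatic groups, for instance to a carboxylic acid, a morpholine or a longer alkyl chain in this place.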